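Moving from 4-methylphenyl to (2-(oxan-4-yl)ethyl)amino

The compounds below may be only part of what the source reports. "The series", "measured", "known", "first", "only" and "open" are said of these compounds alone.

In an ADME assay on microsomes from liver (Mus musculus, strain CD1) for metabolic stability, read by HPLC, using NADPH, with a stated time of 30 min, tested at 0.5 uM (on this read-out lower numbers stand for slow clearance and higher numbers for fast clearance), compound 1 `Cc1ccc(-c2cc(C(=O)NCCCN(C)C)c3cc(Cl)ccc3n2)cc1` gives 1.1 mL.min-1.g-1 and compound 2 `Cc1ccc(-c2cc(C(=O)NCCN3CCCC3)c3cc(Cl)ccc3n2)cc1` gives 2.1 mL.min-1.g-1, so compound 2 stands level with compound 1. Compound 3 `O=C(NCCN1CCCC1)c1cc(NCCC2CCOCC2)nc2ccc(Cl)cc12` brings (2-(oxan-4-yl)ethyl)amino in place of 4-methylphenyl on an aromatic carbon, next to the ring nitrogen. Within the data shown here, the only measured step, a 1.9-fold higher number from compound 1 to compound 2 (0.28 log units; within the scatter), lies on a saturated chain carbon and does not cover this aromatic carbon. With no measured guide to a shift, the expected change is only a 1.2-fold higher number from compound 2 to compound 3 (0.08 log units; within the scatter), none beyond the scatter. Compound 3 is estimated at 2.5 mL.min-1.g-1, with an expected range of 0.8 mL.min-1.g-1 to 7 mL.min-1.g-1.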

Compound 3, intrinsic clearance in microsomes in the Mus musculus assay: 2 mL.min-1.g-1
Compound 3: the middle estimate sits 1.3-fold (0.10 log units) above what was measured; measured number inside the range.
By their numbers in the Mus musculus assay, from the lowest: compounds 1, 3 and 2 (each within the scatter of the next).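

Among these compounds, in the Mus musculus assay, the first measured change at this aromatic carbon, next to the ring nitrogen, gives a 1.1-fold lower number from compound 2 to compound 3 (0.02 log units; within the scatter), so an aromatic 4-methylphenyl and the non-aromatic (2-(oxan-4-yl)ethyl)amino stand level on this read-out. The same change does separate the two compounds in a physicochemical assay for solubility, read by nephelometry, measured as kinetic solubility (on this read-out lower numbers stand for lower solubility and higher numbers for higher solubility), where compound 2 gives 13000 nM and compound 3 gives 230000 nM: the measured solubility of compound 2, 13000 nM, and of compound 3, 230000 nM, an 18-fold higher number (1.25 log units; beyond the scatter)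

As far as these compounds go, whether a morpholin-4-yl group at this carbon would give the same picture remains open. Also open, from the compounds shown here alone, is which part of (2-(oxan-4-yl)ethyl)amino, the amino nitrogen, the chain or the oxane ring, carries the difference in solubility.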